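Replacing Hydroxy With (4-Methylphenyl)amino: An Estimate for Compound 4

The source may report more compounds than this note shows. Statements on the series, on what has been measured and on what is new or still open speak of the compounds shown alone.

Compound 1 `C=CC1=C(C(=O)O)C(c2ccc(F)cc2)OC1`: in a functional assay on A549 cells (Homo sapiens) for cytotoxicity, read by MTT assay, with a stated time of 24 h (a lower number here means a stronger inhibitor, a higher number a weaker inhibitor), compound 1 gives > 100000 nM, a limit of the assay rather than a number.
Compound 2 `C=CC1=C(C(=O)O)C(c2ccc(OC)cc2)OC1`: in this assay compound 2 gives > 100000 nM, again a limit.
Compound 3 `C=CC1=C(C(=O)O)C(c2ccc(OC)c(OC)c2)OC1`: in this assay compound 3 gives > 100000 nM, also a limit.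

Compound 2 therefore stands at the limit of > 100000 nM in this assay, at which 3 of the 3 values shown sit; no number is known for it. The two measured steps, a step that the two limits leave unreadable from compound 1 to compound 2 and a step that the two limits leave unreadable from compound 2 to compound 3, both concern the aromatic ring of the shared core, and neither can be read in size or direction. Compound 4 `C=CC1=C(C(=O)Nc2ccc(C)cc2)C(c2ccc(OC)cc2)OC1` differs from compound 2 by (4-methylphenyl)amino in place of hydroxy on a carbonyl carbon. Within the data shown here, no measured step touches the carbonyl carbon, so the measured steps give no expected size or direction for this change. The writer estimates compound 4 at 30000 nM, with a range from 4000 nM to 200000 nM, which corresponds to an expected step of an at least 3.3-fold lower number from compound 2 to compound 4 (0.52 log units; beyond the scatter).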

Compound 4, half-maximal inhibitory concentration: > 100000 nM
Compound 4: a limit, no number (the forecaster's own chance of this, stated with the estimate: 45%); middle value at least 3.3-fold (0.52 log units) away from the limit.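

Compound 2 and compound 4 both give only a limit, and the step between them cannot be read: the limit of > 100000 nM in this assay, at which 4 of the 4 values shown sit.

The compounds shown leave open what number, if any, any of them would reach in this assay.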